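Moving the chlorine on the benzyl ring of compound 2

The compounds below may be only part of what the source reports. "The series", "measured", "known", "first", "only" and "open" are said of these compounds alone.

Three compounds have been measured in an ADME assay on HeLa cells (Homo sapiens) for inhibition, read by MTT assay; a lower number here means a stronger inhibitor of growth, a higher number a weaker inhibitor of growth:
Compound 1 `Cc1nc(-c2ccc(F)cc2)oc1-c1csc(Cc2ccc(F)cc2)n1` gives 94.9 ug/mL.
Compound 2 `Cc1nc(-c2ccccc2)oc1-c1csc(Cc2ccc(Cl)cc2)n1` gives 124 ug/mL.
Compound 3 `Cc1nc(-c2ccc(F)cc2)oc1-c1csc(Cc2ccccc2)n1` gives 148 ug/mL.

The three numbers fall close together. Compound 2 sits among them with no gap to compound 1 or to compound 3 that goes beyond the usual scatter, so nothing separates it from either.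

Compound 4 `Cc1nc(-c2ccccc2)oc1-c1csc(Cc2cccc(Cl)c2)n1` has not yet been measured. It differs from compound 2 in one place: 3-chlorophenyl in place of 4-chlorophenyl on a saturated chain carbon bound to an aromatic carbon. Among the measured compounds shown here, the only measured step on that same benzyl ring is a 1.6-fold higher number from compound 1 to compound 3 (0.19 log units; within the scatter), which swaps an atom rather than moving one, and it stays within the scatter. For the measured compounds named here, no measured pair shows the same chlorine moved to a different ring position, so nothing directly bears on this change. Going by the values given here, with the one related step flat, no movement beyond the scatter is expected in this assay for compound 4.

The expected step is therefore no change at the digits printed from compound 2 to compound 4 (within the scatter). Compound 4 is estimated at 124 ug/mL, with a likely range from 60 ug/mL to 250 ug/mL.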

Compound 4, concentration for 50% growth inhibition: 68.7 ug/mL
For compound 4 the middle estimate is 1.8-fold (0.26 log units) above the measured one; measured number inside the range.
By their numbers in this assay, from the lowest: compounds 4, 1, 2 and 3 (each within the scatter of the next, the first and the last beyond it).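

In this assay, the step for 3-chlorophenyl in place of 4-chlorophenyl on a saturated chain carbon bound to an aromatic carbon is a 1.8-fold lower number from compound 2 to compound 4 (0.26 log units; within the scatter). Among the compounds shown here, this is the first measured pair in which the same chlorine changes its ring position rather than one atom replacing another. Because the step lies within the scatter, this position accepts either chlorobenzyl arrangement with no change that can be told apart from repeat measurements in this pair. No supporting data are available to explain the result.

The compounds shown leave open whether the same flat result would hold for a larger or differently built group at this place, such as an amine, a carboxylic acid or a longer chain in place of the chlorine. They also leave open whether a fluoro group on the other phenyl ring would alter this step.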